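Phenyl for a Branched Chain: Cytotoxicity Outlook

The compounds below may be only part of what the source reports. "The series", "measured", "known", "first", "only" and "open" are said of these compounds alone.

Measured so far:
Compound 1, `CC(C)CCn1nc(C2CCCCC2)c(O)c(C2=NS(=O)(=O)c3cc(NS(C)(=O)=O)ccc3N2)c1=O`: in an ADME assay on Huh-7 cells (Homo sapiens) for cytotoxicity, with a stated time of 72 h (on this read-out higher numbers stand for lower toxicity in this test and lower numbers for higher toxicity in this test), compound 1 gives > 1000 nM, which is a limit of the assay and not a number.
Compound 2, `CCC(C)CCn1nc(-c2cccs2)c(O)c(C2=NS(=O)(=O)c3cc(NS(C)(=O)=O)ccc3N2)c1=O`: in this assay compound 2 gives > 1000 nM, again a limit rather than a number.

Both compounds share the same core and differ only in the group on the chain carbon bound to the aromatic nitrogen and in the ring on the other side. Among the measured compounds shown here, compound 2 therefore stands at the limit of > 1000 nM in this assay, at which 2 of the 2 values shown sit, and the two values show only that neither compound reached a measurable toxicity; no ordering between them can be read from this. For the measured compounds named here, no pair of measured compounds that differ in one place is available, so no measured step gives a sense of size.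

Compound 3, `CS(=O)(=O)Nc1ccc2c(c1)S(=O)(=O)N=C(c1c(O)c(-c3cccs3)nn(Cc3ccccc3)c1=O)N2`, differs from compound 2 by phenyl in place of 2-methylbutyl on a saturated chain carbon bound to an aromatic nitrogen. No step beyond the usual scatter is expected, so a step that the limit leaves unreadable from compound 2 to compound 3 is the change estimated for this assay. Compound 3 is accordingly expected to give 2000 nM, within a range from 700 nM to 6000 nM, most likely again as a limit.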

Compound 3, half-maximal cytotoxic concentration: > 1000 nM
Compound 3 was reported as a limit; the forecaster's own chance of this, stated with the estimate: 85%; the middle value lies beyond the limit too.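

In this assay, no step can be read from compound 2 to compound 3, because both results are limits and not numbers: the limit of > 1000 nM in this assay, at which 3 of the 3 values shown sit.

The compounds shown leave open how far past that limit each one lies, and whether phenyl in place of 2-methylbutyl changes the toxicity in this test at all.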